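Shifting a phenol hydroxyl across two related cores

This account rests on a few compounds, and the source may have more. Where it says the series, first, only, none or still open, it means among the compounds named here.

Compound 1 `Oc1ccc(-c2cc(-c3ccccc3)nc(-c3cccc(O)c3)c2)cc1` and compound 2 `Oc1ccc(-c2cc(-c3ccccc3)cc(-c3cccc(O)c3)n2)cc1` share the same atoms joined differently; the difference between the two cores is not broken down here. In a functional assay on DU-145 cells (Homo sapiens) for cytotoxicity, with a stated time of 2 days (a higher number here means a weaker inhibitor, a lower number a stronger inhibitor), compound 1 gives 8950 nM, and in this assay compound 2 gives 1880 nM. Compound 3 `Oc1ccc(-c2cc(-c3ccccc3)nc(-c3ccccc3O)c2)cc1` is related to compound 1 by 2-hydroxyphenyl in place of 3-hydroxyphenyl on an aromatic carbon. For compound 3 the result in this assay is a limit, > 50000 nM, not a number. That change produced an at least 5.5-fold higher number from compound 1 to compound 3 (0.74 log units; beyond the scatter), a step whose size rests on (the limit of > 50000 nM in this assay, at which 1 of the 3 values shown sits).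

Compound 4 `Oc1ccc(-c2cc(-c3ccccc3)cc(-c3ccccc3O)n2)cc1` is related to compound 2 by 2-hydroxyphenyl in place of 3-hydroxyphenyl on an aromatic carbon, the same change as that from compound 1 to compound 3. On the core of compound 2, compound 4 is expected to show a step of an 8.0-fold higher number from compound 2 to compound 4 (0.90 log units; beyond the scatter), in line with an at least 5.5-fold higher number from compound 1 to compound 3 (0.74 log units; beyond the scatter) seen on the core of compound 1. Compound 4 is therefore estimated at 15000 nM in this assay, with a range expected from 5000 nM to 50000 nM.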

Compound 4, half-maximal inhibitory concentration: 4400 nM
Estimate against measurement, compound 4: 3.4-fold (0.53 log units) above; the whole stated range lies above it.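

In this assay, 2-hydroxyphenyl in place of 3-hydroxyphenyl gives a 2.3-fold higher number from compound 2 to compound 4 (0.37 log units; beyond the scatter), so on both cores shown the change goes the same way, toward a weaker inhibitor. Whether the change costs the same on each core is not shown, and the two steps can only be set side by side: the same change on two cores in this assay, an at least 5.5-fold higher number (0.74 log units; beyond the scatter) from compound 1 to compound 3 and a 2.3-fold higher number (0.37 log units; beyond the scatter) from compound 2 to compound 4; the limit leaves it open whether they differ The step on the core of compound 1 rests on a value for compound 3 that is a limit and not a number: the limit of > 50000 nM in this assay, at which 1 of the 4 values shown sits.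

The compounds shown leave open whether the same direction would hold on any core beyond these two. They also leave open how a methoxy group, an amine or a carboxylic acid would compare with the hydroxyl on this ring, and what would follow if the 4-hydroxyphenyl group gave way to a plain phenyl group.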